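A few compounds are considered here, and "the series" means these few. Any claim that something is new, unique, unknown or untested is made for them only; others in the source may bear on it.

Measured compounds:
compound 1, `COc1cc([C@H]2c3cc(O)c(O)cc3C=C(C=O)[C@@H]2CO)ccc1O`, 380 nM
compound 2, `COc1cc(-c2cc(C=O)cc3ccc(O)c(OC)c23)ccc1O`, 200 nM

This account concerns two measured compounds and one that has not yet been measured. In a functional assay on RAW264.7 cells (Mus musculus) for inhibition, read by Griess assay, with a stated time of 24 h (on this read-out lower numbers stand for stronger inhibition and higher numbers for weaker inhibition), compound 1 gives 380 nM, and compound 2 gives 200 nM in this assay. Compound 1 has the highest of the two numbers, but its nearest neighbour, compound 2, differs by a gap that falls within the scatter, so the two values cannot be told apart with confidence.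

The step followed here leads from compound 1 to compound 3, `COc1cc([C@H]2c3cc(O)c(OC)cc3C=C(C=O)[C@@H]2CO)ccc1O`, which is not yet measured in this assay. The counted difference is methyl in place of hydrogen on an oxygen on an aromatic ring. Within the data shown here, no measured pair shows this change, so its effect cannot be read from the data; the two measured values alone give no guidance on it.

The expectation for compound 3 is a small step, no larger than the scatter or slightly beyond it, towards a higher number in this assay, written as a 1.4-fold higher number from compound 1 to compound 3 (0.16 log units; within the scatter). Compound 3 is therefore estimated at 550 nM, with a range from 200 nM to 1500 nM.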

Compound 3, half-maximal inhibitory concentration: 3540 nM
Compound 3: the middle estimate sits 6.4-fold (0.81 log units) below what was measured; measured number above the stated range.
By their numbers in this assay, from the lowest: compounds 2 and 1 (each within the scatter of the next); then compound 3.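

In this assay the change from hydroxy to methoxy at this position on the core of compound 1 proves to be far from neutral: methyl in place of hydrogen on an oxygen on an aromatic ring gives a 9.3-fold higher number from compound 1 to compound 3 (0.97 log units; beyond the scatter) and so lies beyond the scatter. Among these compounds, this is the first measured pair to carry this change, and it shows that a single added methyl at this oxygen is enough to move the number well outside the range in which compounds 1 and 2 lie, with the free hydroxy going with the lower number in this one pair. Nothing among the available data explains the size of this step, and no measurement bears on its cause.

The compounds shown leave open whether the step follows from gaining the methyl or from losing the hydrogen on the oxygen, a question that an amine or a fluorine in place of the hydroxy could help to separate. They also leave open how an ethoxy group or a longer chain on this same oxygen would read, and whether the same change on another oxygen of the core would give a step of similar size.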